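Swapping the aryl group on a stable anilino core

A few compounds are considered here, and "the series" means these few. Any claim that something is new, unique, unknown or untested is made for them only; others in the source may bear on it.

Measured compounds:
compound 1, `FC(F)(F)c1cccc(-c2nc3cnc(Nc4ccccn4)cc3[nH]2)c1`, 47%
compound 2, `FC(F)(F)c1cccc(-c2nc3cnc(Nc4ccncn4)cc3[nH]2)c1`, 89%
compound 3, `FC(F)(F)c1ccc(Nc2cc3[nH]c(-c4cccc(C(F)(F)F)c4)nc3cn2)nc1`, 91%

In an ADME assay on microsomes from liver (Mus musculus) for metabolic stability, read by LC-MS, with a stated time of 30 min, tested at 0.1 uM (a higher number here means that more of the compound is left, a lower number that less of the compound is left), compound 3 gives 91%, the highest of the three numbers. Its nearest neighbour is compound 2, which differs only within the scatter: a number 2 percentage points higher from compound 2 to compound 3 (within the scatter). The gap to compound 1 is large: a number 44 percentage points higher from compound 1 to compound 3 (beyond the scatter). Both of the large steps seen so far, a number 42 percentage points higher from compound 1 to compound 2 (beyond the scatter) and a number 44 percentage points higher from compound 1 to compound 3 (beyond the scatter), concern the group carried on the ring nitrogen, not the group on the five-membered ring.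

Compound 4, `FC1(F)CCC(c2nc3cnc(Nc4ccc(C(F)(F)F)cn4)cc3[nH]2)CC1`, keeps that side of compound 3 unchanged and alters the other end: 4,4-difluorocyclohexyl in place of 3-(trifluoromethyl)phenyl on an aromatic carbon

Among the measured compounds shown here, no measured step touches this position, so none of the three steps bears directly on it. With the shared anilino side retained, the expectation is that compound 4 stays in the upper region set by compounds 2 and 3, while the lack of any precedent for the change itself widens the uncertainty. Compound 4 is therefore expected to show a number 13 percentage points lower from compound 3 to compound 4 (beyond the scatter), and its estimated value in this assay is 78%, within a range of 50% to 95%.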

Compound 4, percent of the compound remaining: 73%
Compound 4: middle estimate off by 5 percentage points, on the high side, and the stated range covers the measured number.
By their numbers in this assay, from the lowest: compound 1; then compound 4; then compounds 2 and 3 (each within the scatter of the next).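

At the place this change touches, an aromatic carbon of a five-membered aromatic ring, between two ring nitrogen atoms, the compounds now show a first effect: with the 5-(trifluoromethyl)pyridin-2-yl group held fixed, this assay records a number 18 percentage points lower from compound 3 to compound 4 (beyond the scatter), so this end of the molecule also bears on the read-out. The change alters more than one feature at once, since 3-(trifluoromethyl)phenyl is an aromatic ring of carbon only, 4,4-difluorocyclohexyl is a non-aromatic ring of carbon only, and the fluorine sits differently on each, so this one step cannot assign the drop to any one of these features. Nothing shown here gives a measured reason for the lower number.

Going by these compounds, it remains open whether an unsubstituted cyclohexyl, a plain phenyl, or a cyclohexyl carrying a hydroxyl group or an amine would behave like 4,4-difluorocyclohexyl or like 3-(trifluoromethyl)phenyl. On these data alone, it is also open whether a step of this size would recur with the pyrimidin-4-yl or pyridin-2-yl groups in place of the 5-(trifluoromethyl)pyridin-2-yl group.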